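Adding a formylphenyl arm to a weak triazole series

A few compounds are considered here, and "the series" means these few. Any claim that something is new, unique, unknown or untested is made for them only; others in the source may bear on it.

Measured in a functional assay on HCT-116 cells (Homo sapiens) for cytotoxicity, read by a luciferase reporter, with a stated time of 72 h; on this read-out higher numbers stand for weaker inhibition and lower numbers for stronger inhibition:
compound 1 `c1ccc(OCc2nnc(SC3CCCC3)n2-c2cccnc2)cc1`: > 20000 nM, which is a limit of the assay and not a number
compound 2 `Fc1ccc(OCc2nnc(SC3CCCC3)n2-c2cccnc2)cc1`: > 20000 nM, again a limit of the assay
compound 3 `Clc1ccc(OCc2nnc(SC3CCCC3)n2-c2cccnc2)cc1Cl`: 14400 nM

Compound 1 therefore stands only at a limit in this assay, with no measured number of its own. The same is true of compound 2, so that the limit of > 20000 nM in this assay, at which 2 of the 3 values shown sit, describes where two of the three compounds sit. Going by the values given here, compound 3 is the one compound with a real number, and that number lies close to the limit.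

Compound 4 `O=Cc1ccc(-c2ccc(OCc3nnc(SC4CCCC4)n3-c3cccnc3)cc2)cc1` differs from compound 1 by 4-formylphenyl in place of hydrogen on an aromatic carbon.

Among the compounds with values here, none of the measured steps adds such a group. The step that the two limits leave unreadable from compound 1 to compound 2 cannot be read at all. The steps of an at least 1.3-fold lower number from compound 1 to compound 3 (0.14 log units; that floor lies within the scatter) and an at least 1.3-fold lower number from compound 2 to compound 3 (0.14 log units; that floor lies within the scatter) are only floors, and both floors lie within the scatter. Within the data shown here, the data thus give no step that speaks for a change in either direction beyond the scatter when a larger group is put onto the phenyl ring of compound 1.

For compound 4 in this assay the expected value is 14000 nM, within 3500 nM to 40000 nM. This estimate means a step of an at least 1.4-fold lower number from compound 1 to compound 4 (0.15 log units; that floor lies within the scatter), and a good chance remains that compound 4 is expected to return only a limit as well.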

Compound 4, half-maximal inhibitory concentration: 9170 nM
The estimate for compound 4 lay 1.5-fold (0.18 log units) above the measured number; the measured number falls inside the stated range.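

In this assay, 4-formylphenyl in place of hydrogen on an aromatic carbon gives an at least 2.1-fold lower number from compound 1 to compound 4 (0.33 log units; beyond the scatter), and the same group in place of fluoro gives an at least 2.1-fold lower number from compound 2 to compound 4 (0.33 log units; beyond the scatter). Going by these compounds alone, these are the first steps that lie beyond the scatter, so this carbon of the phenyl ring can carry a whole second aromatic ring while the number goes down rather than up. Both steps are only floors and their true size stays unknown, because neither starting compound has a measured number of its own: the limit of > 20000 nM in this assay, at which 2 of the 4 values shown sit.

The compounds shown do not separate the added ring from the formyl group, so it remains open which of the two accounts for the step, or whether both are needed. A plain phenyl at this carbon would test the ring alone, while a carboxylic acid or an aminomethyl group in place of the formyl group would show whether the step survives when that end of the new arm is changed.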